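A few compounds are considered here, and "the series" means these few. Any claim that something is new, unique, unknown or untested is made for them only; others in the source may bear on it.

Measured compounds:
- compound 1 `Nc1ncnc2c1nc(O)n2[C@@H]1O[C@@H]2COP(=O)(O)O[C@H]2[C@H]1O`, no result reported
- compound 2 `[N-]=[N+]=Nc1nc2c(N)ncnc2n1[C@@H]1O[C@@H]2COP(=O)(O)O[C@H]2[C@H]1O`, 633%
- compound 3 `CSc1nc2c(N)ncnc2n1[C@@H]1O[C@H](COP(=O)(O)O)[C@@H](O)[C@H]1O`, 112%

Three compounds share a core in which an adenine-like base is joined to a sugar carrying a phosphate. In a functional assay on the whole organism for activation, with Mus musculus as the target, with stated times of 14 days and 2 h, at a dose of 30 mg/kg by the intravenous route (a lower number here means a weaker effect, a higher number a stronger effect of the compound at the dose given), compound 2 gives 633%, the higher of the two numbers; compound 3 gives 112%, a difference that lies beyond the usual scatter. Compound 1 has no number in this assay.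

Compound 4 is `Nc1ncnc2c1nc(SCc1ccccc1)n2[C@@H]1O[C@@H]2COP(=O)(O)O[C@H]2[C@H]1O`. It differs from compound 2 in one place: benzylsulfanyl in place of azido on an aromatic carbon. Compound 3 shows that a sulfur-bearing group on the core, together with an open rather than ring-closed phosphate, goes with a far lower value than compound 2. Among the measured compounds shown here, no step between two measured compounds isolates the change made here, so the size of the step is uncertain, but a fall is expected.

The estimated step of a number 383 percentage points lower from compound 2 to compound 4 (beyond the scatter) is therefore downward and beyond the scatter. Compound 4 is expected to give 250%, within a range from 80% to 550%.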

Compound 4, a percentage reported as activity, at one dose (the size of the read-out at that dose, not a potency): 195%
Estimate against measurement, compound 4: 55 percentage points above; low and high end bracket the measured number.
By their numbers in this assay, from the lowest: compound 3; then compound 4; then compound 2.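

Replacing azido with benzylsulfanyl on the aromatic carbon between two ring nitrogen atoms gives a number 438 percentage points lower from compound 2 to compound 4 (beyond the scatter) in this assay. Among the compounds shown here, both compounds keep the same ring-closed phosphate, so this is the first comparison in which a change at this position stands alone, and it shows that the read-out at this dose depends strongly on the group placed there. Nothing available explains the fall.

This single change replaces the whole group, so it remains unclear whether the lower value goes with the sulfur atom, the benzyl part or the loss of azido. An amine or a benzyloxy group in the same place, on the same ring-closed phosphate core, would help separate these possibilities.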